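Halogen swap on a dicyano-aryl enaminone series

The compounds below may be only part of what the source reports. "The series", "measured", "known", "first", "only" and "open" are said of these compounds alone.

Measured so far:
- compound 1, `Cc1ccc(C(=O)C(=C2NCCN2)c2c(Cl)c(F)c(C#N)c(F)c2C#N)cc1`: 0.03 ug/mL
- compound 2, `Cc1ccc(C(=O)C(=C2NCCN2)c2c(F)c(F)c(C#N)c(F)c2C#N)cc1`: 0.04 ug/mL
- compound 3, `N#Cc1c(F)c(Cl)c(C(C(=O)c2ccc(F)cc2)=C2NCCCCN2)c(C#N)c1F`: 0.1 ug/mL

Compounds 1 and 2 share one core and differ only by fluoro in place of chloro on an aromatic carbon. In a functional assay on HL-60 cells (Homo sapiens) for antiproliferative activity, read by MTT assay (a lower number here means a stronger inhibitor, a higher number a weaker inhibitor), this change gave a 1.3-fold higher number from compound 1 to compound 2 (0.12 log units; within the scatter). Compound 3 carries a different core; the difference between the two cores is not broken down here. Compound 4, `N#Cc1c(F)c(F)c(C(C(=O)c2ccc(F)cc2)=C2NCCCCN2)c(C#N)c1F`, is not yet measured and differs from compound 3 by fluoro in place of chloro on an aromatic carbon, the same change as from compound 1 to compound 2, at a place described in the same words.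

Among the measured compounds shown here, for compound 4 in this assay the expected step is a 1.3-fold higher number from compound 3 to compound 4 (0.11 log units; within the scatter), resting on the single earlier example, in which the step from compound 1 to compound 2 stayed within scatter. Compound 4 is therefore estimated at 0.13 ug/mL, with a likely range from 0.06 ug/mL to 0.3 ug/mL.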

Compound 4, half-maximal inhibitory concentration: 0.1 ug/mL
For compound 4 the middle estimate is 1.3-fold (0.11 log units) above the measured one; measured number inside the range.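

In this assay, fluoro in place of chloro on an aromatic carbon gave no change at the digits printed from compound 3 to compound 4 (within the scatter), and the two cores can be set side by side: the same change on two cores in this assay, a 1.3-fold higher number (0.12 log units; within the scatter) from compound 1 to compound 2 and no change at the digits printed (within the scatter) from compound 3 to compound 4, 1.3-fold (0.12 log units) apart, within the scatter of two such steps

Across these two pairs, the swap therefore carries from one core to the other without a step beyond the scatter, and chloro and fluoro at this place read alike in this assay. This does not show that the swap would stay silent on a further core, and since neither step exceeds the scatter, the pairs do not test whether a real effect transfers.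

On these data alone, whether a bromo, a methoxy or an amine at the same aromatic carbon would shift the number remains open. Also open, as far as these compounds go, is which part of the difference between the two cores matters, as they differ in more than one place.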